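The source may report more compounds than this note shows. Statements on the series, on what has been measured and on what is new or still open speak of the compounds shown alone.

Compound 1 `CCOC(=O)C(=O)Nc1nc(-c2ccc(F)cc2)cs1` gives > 10 mg/kg (a limit)
Compound 2 `CCOC(=O)C(=O)Nc1nc(-c2ccc(OC)cc2)cs1` gives about 10 mg/kg

Among the measured compounds shown here, in a functional assay on the whole organism with Rattus norvegicus as the target (on this read-out lower numbers stand for an effect already at smaller amounts and higher numbers for an effect only at larger amounts of compound), compound 2 gives about 10 mg/kg as the only true number so far. The value of compound 1 is a limit. Compound 3 `CCOC(=O)C(=O)Nc1nc(-c2ccc(Oc3ccccc3)cc2)cs1` has phenyl in place of methyl on an oxygen on an aromatic ring. For the measured compounds named here, the one measured step (a number no higher from compound 1 to compound 2 (the limit leaves the size open)) put methoxy in place of fluoro, but its size stays open, so it sets no size for this change. Going by the values given here, no step clearly beyond the scatter, in either direction, is therefore expected in this assay for this change. For compound 3 the expected step is no change at the digits printed from compound 2 to compound 3 (within the scatter) as a rough estimate. Compound 3 is estimated at 10 mg/kg with a range from 4 mg/kg to 25 mg/kg in all.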

Compound 3, dose for half-maximal effect: > 30 mg/kg
Compound 3 gave a limit, no number (the forecaster's own chance of this, stated with the estimate: 40%); at least 3.0-fold (0.47 log units) between middle value and limit.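

In this assay, the change from methoxy to phenoxy gives an at least 3.0-fold higher number from compound 2 to compound 3 (0.47 log units; beyond the scatter), so this oxygen on the aromatic ring does not accept phenyl in place of methyl without loss of effect, a cost that the earlier pair could not size. The value of compound 3 is a limit: the limit of > 30 mg/kg in this assay, at which 1 of the 3 values shown sits. Compound 1 and compound 3 both stand at limits, and the step between them cannot be read.

On these data alone, it remains open whether an ethyl or a benzyl group on this oxygen would keep the effect of compound 2. As far as these compounds go, it also remains open how an amine in place of the methoxy would read out.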